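Agonist series at the chemokine receptor: a chain swap

The source may hold more compounds than are shown below. What is called first, only, known or untested is meant among the compounds shown, and "the series" means these compounds.

Compound 1 `c1ccc2c(c1)CN[C@@H](CN(CCCCNCC1CCOCC1)[C@H]1CCCc3cccnc31)C2` and compound 2 `c1ccc2c(c1)CN[C@@H](CN(Cc1ccc(CNCc3ccncc3)cc1)[C@H]1CCCc3cccnc31)C2` share a core and differ in the group on the tertiary amine. In a functional assay on cells for agonist activity at C-X-C chemokine receptor type 4 (Homo sapiens), read by fluorescence and calcium flux, with a stated time of 90 s (a higher number here means that more compound is needed for the effect, a lower number that less compound is needed), compound 1 gives only a limit of > 30000 nM. In this assay compound 2 likewise gives only a limit, > 30000 nM. Compound 1 thus stands at the limit of > 30000 nM in this assay, at which 2 of the 2 values shown sit, with no number of its own. Compound 3 `C(=C/CN(C[C@H]1Cc2ccccc2CN1)[C@H]1CCCc2cccnc21)\CNCc1cccnc1` carries the change (a group of 11 heavy atoms (9 carbon, 2 nitrogen; one six-membered aromatic ring with 1 hetero atom) in place of a group of 11 heavy atoms (9 carbon, 1 nitrogen, 1 oxygen; one six-membered non-aromatic ring with 1 hetero atom), on a saturated chain carbon bound to an amine nitrogen). Going by the values given here, no measured step shows what such a change does here, so the expected step is a step that the limit leaves unreadable from compound 1 to compound 3, none beyond the scatter. Compound 3 is therefore estimated at 40000 nM, between 5000 nM and 150000 nM.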

Compound 3, half-maximal effective concentration: > 30000 nM
Compound 3 gave a limit, no number; the forecaster's own chance of this, stated with the estimate: 70%; the middle value lies beyond the limit too.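

Going by these compounds alone, compound 1 and compound 3 both give only limits in this assay, so no step between them can be read. The compounds shown leave open which change, if any, would give a measurable half-maximal effective concentration in this series.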